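The compounds below may be only part of what the source reports. "The series", "measured", "known", "first", "only" and "open" are said of these compounds alone.

Of the compounds shown here, two of a shared core have been measured so far. Compound 1 `O=C(NC1CCN(Cc2ccccc2)CC1)c1coc2cc(Br)ccc2c1=O` and compound 2 `O=C(NCCC1CCN(Cc2ccccc2)CC1)c1coc2ccccc2c1=O` share the amide linked to a benzylpiperidine, but differ in the length of that link and in a bromo group present only in compound 1. In an assay on isolated protein for inhibition of Amine oxidase [flavin-containing] A (Homo sapiens), read by fluorescence and Amplex Red, with stated times of 15 min and 20 min, tested at 100 uM (a lower number here means less inhibition, a higher number more inhibition at the concentration tested (going by the name of the read-out)), compound 1 gives 31.6%. In this assay compound 2 gives 68.6%. Compound 2 therefore stands highest of the two numbers, and its distance from compound 1 lies beyond the scatter of this measurement. For the measured compounds named here, because the two compounds differ in more than one place, no single step between them is defined, and the two values show only that compound 2 is the higher of the pair.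

Compound 3 `O=C(NCCC1CCN(Cc2ccccc2)CC1)c1coc2ccc(Br)cc2c1=O` follows from compound 2 by one change: bromo in place of hydrogen on an aromatic carbon. Going by the values given here, no step of this kind has been measured among the known compounds, so the size and direction of its effect in this assay cannot be read from them. A step of modest size, not clearly beyond the scatter, is expected from compound 2 to compound 3, namely a number 6.6 percentage points lower from compound 2 to compound 3 (within the scatter). For compound 3 in this assay the estimate is 62%, with a likely range from 40% to 84%.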

Compound 3, a percentage reported as inhibition, at one concentration (the size of the read-out at that concentration, not a potency): 48.2%
Beside the measured number, compound 3's estimate is 13.8 percentage points above it; low and high end bracket the measured number.
By their numbers in this assay, from the lowest: compound 1; then compound 3; then compound 2.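

In this assay, for the compounds shown here, the only step that can be read so far is a number 20.4 percentage points lower from compound 2 to compound 3 (beyond the scatter), and it shows that this one change, bromo in place of hydrogen on an aromatic carbon, is enough to shift the read-out at the concentration tested. Compound 1 and compound 2 differ in more than one place, so that pair could not show the effect of bromo alone; here the direction at this place, meta to a fused ring and para to a fused ring, is downward, while compound 3 still gives 48.2%. Nothing among the data shown accounts for the size of this step.

The compounds shown leave open whether the step is particular to bromo or would also appear with another group on the same carbon, such as chloro, methoxy or an amine. They also leave open how bromo behaves elsewhere on this ring, since compound 1 carries its bromo at another place and also differs in the link to the benzylpiperidine.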